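The compounds below may be only part of what the source reports. "The series", "measured", "known", "first", "only" and "open" are said of these compounds alone.

Compound 1 `OC[C@H]1O[C@@H](n2cnc3c(NCc4cccc(Br)c4)ncnc32)[C@H](O)[C@@H]1O` carries a 3-bromophenyl on a saturated chain carbon bound to a nitrogen on an aromatic ring. In a functional assay on HOS cells (Homo sapiens) for antiproliferative activity, with a stated time of 72 h (a lower number here means a stronger inhibitor, a higher number a weaker inhibitor), compound 1 gives only a limit, > 166000 nM. Compound 2 `Cc1ccc(CNc2ncnc3c2ncn3[C@@H]2O[C@H](CO)[C@@H](O)[C@H]2O)cc1` likewise gives only a limit in this assay, > 166000 nM. Compound 3 `COc1ccc(CNc2ncnc3c2ncn3[C@@H]2O[C@H](CO)[C@@H](O)[C@H]2O)c(OC)c1` also gives only a limit in this assay, > 166000 nM. The steps a step that the two limits leave unreadable from compound 1 to compound 2, a step that the two limits leave unreadable from compound 1 to compound 3 and a step that the two limits leave unreadable from compound 2 to compound 3 stay unreadable because of the limit of > 166000 nM in this assay, at which 3 of the 3 values shown sit. Compound 4 `OC[C@H]1O[C@@H](n2cnc3c(NCc4cc(O)cc(O)c4)ncnc32)[C@H](O)[C@@H]1O` is not yet measured; it differs from compound 1 by 3,5-dihydroxyphenyl in place of 3-bromophenyl on a saturated chain carbon bound to a nitrogen on an aromatic ring. Among the measured compounds shown here, no measured step reads on this change, and every variation of the group on that saturated chain carbon so far has stayed at the limit. Compound 4 is therefore expected to remain at the limit as well, the expected step being a step that the limit leaves unreadable from compound 1 to compound 4. The estimate for compound 4 is 200000 nM, with a range from 80000 nM to 1000000 nM.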

Compound 4, half-maximal inhibitory concentration: > 166000 nM
Compound 4: no number, only a limit; the forecaster's own chance of this, stated with the estimate: 85%; the middle value is on the limit's open side.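

Among the compounds shown here, no step from compound 4 to compound 1, compound 2 or compound 3 can be read, because all four compounds give only a limit: the limit of > 166000 nM in this assay, at which 4 of the 4 values shown sit.

In this assay the compounds shown leave open which group on that saturated chain carbon, if any, would give a readable value.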